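Aryl Group Exchange on a Shared Lactam Core

The compounds below may be only part of what the source reports. "The series", "measured", "known", "first", "only" and "open" are said of these compounds alone.

Compound 1 `CC1(C)[C@H]2CC[C@]1(C)N(Cc1cn(-c3ccc(C#N)cc3)nn1)C(=O)C2` gives 90 nM in a functional assay on LoVo cells (Homo sapiens) for inhibition, read by MTT assay, with a stated time of 24 h; on this read-out lower numbers stand for stronger inhibition and higher numbers for weaker inhibition.
Compound 2 `Cc1ccc(-n2cc(CN3C(=O)C[C@@H]4CC[C@@]3(C)C4(C)C)nn2)cc1` gives 50 nM in this assay.
Compound 3 `COc1cccc(-n2cc(CN3C(=O)C[C@@H]4CC[C@@]3(C)C4(C)C)nn2)c1` gives 80 nM in this assay.

Among these three, compound 1 stands with the highest number, yet its nearest neighbour is compound 3 at a 1.1-fold lower number from compound 1 to compound 3 (0.05 log units; within the scatter) and its furthest is compound 2 at a 1.8-fold lower number from compound 1 to compound 2 (0.26 log units; within the scatter), so neither gap rises above the scatter. The three aryl groups on the ring nitrogen therefore give numbers that cannot be told apart on this read-out.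

Compound 4 `Cc1cccc(-n2cc(CN3C(=O)C[C@@H]4CC[C@@]3(C)C4(C)C)nn2)c1` is the next member, awaiting measurement. It differs from compound 1 as follows: 3-methylphenyl in place of 4-cyanophenyl on an aromatic nitrogen. Within the data shown here, two measured steps bear on it. The exchange of cyano for methyl on the aromatic carbon, going from compound 1 to compound 2, gave a 1.8-fold lower number from compound 1 to compound 2 (0.26 log units; within the scatter); the exchange of the whole aryl group for a 3-methoxyphenyl, going from compound 1 to compound 3, gave a 1.1-fold lower number from compound 1 to compound 3 (0.05 log units; within the scatter); and between those two aryl groups the step was a 1.6-fold higher number from compound 2 to compound 3 (0.20 log units; within the scatter). Every change on this aryl group so far has stayed inside the scatter, and no step is expected beyond it here either.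

Compound 4 is therefore expected to give 65 nM in this assay, in the range 30 nM to 140 nM, which means an expected step of a 1.4-fold lower number from compound 1 to compound 4 (0.14 log units; within the scatter).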

Compound 4, half-maximal inhibitory concentration: 50 nM
The estimate for compound 4 lay 1.3-fold (0.11 log units) above the measured number, and the stated range covers the measured number.
By their numbers in this assay, from the lowest: compounds 2, 4, 3 and 1 (each within the scatter of the next).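

In this assay, the swap of 4-cyanophenyl for 3-methylphenyl on the aromatic nitrogen gives a 1.8-fold lower number from compound 1 to compound 4 (0.26 log units; within the scatter), and the exchange of methoxy for methyl on the aromatic carbon gives a 1.6-fold lower number from compound 3 to compound 4 (0.20 log units; within the scatter), so a change in the substituent at the same place on the phenyl ring again stays inside the scatter. Among these compounds, compound 4 also supplies the first pair in which one group, methyl, sits at two different places on that phenyl ring, and 3-methylphenyl in place of 4-methylphenyl gives no change at the digits printed from compound 2 to compound 4 (within the scatter), so on this read-out the two placements of methyl cannot be told apart, and all four substituted phenyl groups now fall within the scatter of one another. No measurement shown here gives a reason why these aryl groups read alike.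

The compounds shown leave open whether anything other than a singly substituted phenyl on this aromatic nitrogen, such as a plain benzyl, a longer alkyl chain or a phenyl bearing a carboxylic acid or an amine, would move the number beyond the scatter. They also leave open how the number responds to a change anywhere on the shared core, including the methylene link that joins it to the five-membered aromatic ring.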